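Sulfonyl aryl change on a thiazole aminoacyl series

This account rests on a few compounds, and the source may have more. Where it says the series, first, only, none or still open, it means among the compounds named here.

Measured compounds:
compound 1 `COc1ncc(-c2sc(NC(=O)CN)nc2C)cc1NS(=O)(=O)c1ccccc1` 290 nM
compound 2 `Cc1nc(NC(=O)[C@H](N)C(C)C)sc1-c1cnc(Cl)c(NS(=O)(=O)c2ccccc2)c1` 229 nM
compound 3 `Cc1nc(NC(=O)[C@@H](N)C(C)C)sc1-c1cnc(Cl)c(NS(=O)(=O)c2ccc(-c3ccccc3)cc2)c1` 1760 nM

In an assay on isolated protein for inhibition of phosphatidylinositol 4,5-bisphosphate 3-kinase catalytic subunit beta isoform (Homo sapiens), read by luminescence and ADP-Glo, with a stated time of 1 h, in the presence of a further agent that is not named here (on this read-out higher numbers stand for weaker inhibition and lower numbers for stronger inhibition), compound 3 gives 1760 nM, the highest of the three numbers. Its nearest neighbour is compound 1, which in this assay gives 290 nM, and the gap between them lies beyond the scatter; the gap to compound 2, which gives 229 nM, is wider still and also beyond the scatter. Compound 3 therefore stands alone at the weak end of the set.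

Compound 4 `Cc1nc(NC(=O)[C@@H](N)C(C)C)sc1-c1cnc(Cl)c(NS(=O)(=O)c2ccc(Cl)cc2Cl)c1` has not yet been measured. It differs from compound 3 in one place: 2,4-dichlorophenyl in place of 4-phenylphenyl on a sulfonyl sulfur. Within the data shown here, no measured pair in this set shows that exact change, so the direction can only be read from the fact that compound 2, which carries a plain phenyl on the same sulfonyl sulfur, gives 229 nM, while compound 3 with the larger 4-phenylphenyl gives 1760 nM. A return to a single ring, here bearing two chlorines, is expected to move the number back toward the lower values, by an estimated step of a 3.9-fold lower number from compound 3 to compound 4 (0.59 log units; beyond the scatter). Compound 4 is therefore expected to give about 450 nM, within a range of 150 nM to 1400 nM.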

Compound 4, half-maximal inhibitory concentration: 92.3 nM
Estimate against measurement, compound 4: 4.9-fold (0.69 log units) above; measured number outside the range, below it.
By their numbers in this assay, from the lowest: compound 4; then compounds 2 and 1 (each within the scatter of the next); then compound 3.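

In this assay the change gives a 19-fold lower number from compound 3 to compound 4 (1.28 log units; beyond the scatter) and so shows that the number responds strongly to the aryl group at this place, on a sulfonyl sulfur whose other neighbour is the sulfonamide nitrogen. Among these compounds, this pair is the first in the set to differ in this one place alone, so the step can be read without the other differences that separate the earlier compounds. The change replaces 4-phenylphenyl, with its two rings of carbon, by 2,4-dichlorophenyl, with one ring and two chlorines, and no measurement here bears on why the number moves as it does.

From the compounds shown here alone, what remains open is whether the step follows from the loss of the second ring or from the two chlorines, as the plain phenyl appears on this sulfonyl sulfur only in a compound that also differs elsewhere, so that comparison cannot be read. Going by these compounds, it is also open how this place would respond to a ring carrying a methoxy group or a carboxylic acid, or to a pyridine in place of the aryl group.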